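The source may report more compounds than this note shows. Statements on the series, on what has been measured and on what is new or still open speak of the compounds shown alone.

Values in a functional assay (muscle tissue) for inhibition, with Homo sapiens as the target; on this read-out higher numbers stand for weaker inhibition and lower numbers for stronger inhibition:
- compound 1 `O=C(N[C@@H](CCC(=O)N1CCN(c2cccc(NC3=NCCCN3)c2)CC1)C(=O)O)OCc1ccccc1` gives 1.1 nM
- compound 2 `CCOC(=O)N[C@@H](CCC(=O)N1CCN(c2cccc(NC3=NCCCN3)c2)CC1)C(=O)O` gives 2.1 nM
- compound 3 `CC(C)COC(=O)N[C@@H](CCC(=O)N1CCN(c2cccc(NC3=NCCCN3)c2)CC1)C(=O)O` gives 0.91 nM

Compound 3 stands at 0.91 nM. Its smallest measured step is a 1.2-fold lower number from compound 1 to compound 3 (0.08 log units; within the scatter) and its largest is a 2.3-fold lower number from compound 2 to compound 3 (0.36 log units; beyond the scatter).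

The next compound is compound 4 `Cc1cc(C)c(S(=O)(=O)N[C@@H](CCC(=O)N2CCN(c3cccc(NC4=NCCCN4)c3)CC2)C(=O)O)c(C)c1`, and the change is (2,4,6-trimethylphenyl)sulfonyl in place of isobutoxycarbonyl on an amine nitrogen. The measured steps bear on this only indirectly, as each alters just the chain or phenyl end of the group on that nitrogen. One is a 1.9-fold higher number from compound 1 to compound 2 (0.28 log units; within the scatter), and the largest is the modest 2.3-fold lower number from compound 2 to compound 3 (0.36 log units; beyond the scatter). Among the measured compounds shown here, no measured compound carries a sulfonyl group there, so the replacement itself is untested. The aromatic ring that enters has some precedent in compound 1 1.1 nM, whose group also holds one. No shift beyond the scatter is therefore expected in this assay, though with wide uncertainty. The expected step is a 1.1-fold lower number from compound 3 to compound 4 (0.06 log units; within the scatter). For compound 4 the estimated value is 0.8 nM, with an expected range of 0.2 nM to 3.5 nM.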

Compound 4, half-maximal inhibitory concentration: > 10 nM
Compound 4: a limit, no number; the forecaster's own chance of this, stated with the estimate: 3%; middle value at least 12-fold (1.09 log units) from the limit.
By their numbers in this assay, from the lowest: compounds 3, 1 and 2 (each within the scatter of the next, the first and the last beyond it). At a limit, above all of these: compound 4.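

In this assay compound 4 gives > 10 nM, which is a limit and not a number. On the amine nitrogen, (2,4,6-trimethylphenyl)sulfonyl weakens inhibition relative to all three earlier groups: an at least 10-fold higher number from compound 3 to compound 4 (1.04 log units; beyond the scatter), an at least 4.7-fold higher number from compound 2 to compound 4 (0.67 log units; beyond the scatter) and an at least 9.0-fold higher number from compound 1 to compound 4 (0.95 log units; beyond the scatter). The position is therefore not indifferent to what it carries, although isobutoxycarbonyl, ethoxycarbonyl and benzyloxycarbonyl all stay close together, and the aromatic ring of compound 1 shows that an aromatic ring in this group is not enough on its own to produce the loss.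

Going by these compounds, whether the loss follows the sulfonyl link or the trimethyl-substituted ring remains open, and a plain phenylsulfonyl or methylsulfonyl group would separate the two. The true size of the loss also remains open, since the steps rest on a limit: the limit of > 10 nM in this assay, at which 1 of the 4 values shown sits.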